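The compounds below may be only part of what the source reports. "The series", "measured", "known", "first", "only" and "open" are said of these compounds alone.

Compound 1 `CCCCCCCCCCCCCCNC(=O)[C@H](CO)/N=C/c1ccc([N+](=O)[O-])cc1`, compound 2 `CCCCCCCCCCCCCCNC(=O)[C@H](CO)NCc1ccccc1OC` and compound 3 `CCCCCCCCCCCCCCNC(=O)[C@H](CO)/N=C/c1cccc(OC)c1` share one core and were all tested in a functional assay on cells (Homo sapiens) for cytotoxicity, read by MTT assay, with a stated time of 24 h; on this read-out lower numbers stand for stronger inhibition and higher numbers for weaker inhibition. Compound 1 gives 217000 nM, the highest of the three numbers. Compound 2 gives 100000 nM, while compound 3 gives 31300 nM. The unmeasured compound 4 `CCCCCCCCCCCCCCNC(=O)[C@H](CO)/N=C/c1cccc(C)c1` differs from compound 1 in one place: 3-methylphenyl in place of 4-nitrophenyl on a carbon with a double bond to nitrogen. The step that bears most directly is a 6.9-fold lower number from compound 1 to compound 3 (0.84 log units; beyond the scatter), where a 3-methoxyphenyl replaced the same 4-nitrophenyl. The step of a 3.2-fold lower number from compound 2 to compound 3 (0.50 log units; beyond the scatter) concerns another change and bears less. A step of similar size and downward direction is expected here, namely a 5.4-fold lower number from compound 1 to compound 4 (0.73 log units; beyond the scatter). Compound 4 is therefore estimated at 40000 nM, within a range from 12000 nM to 130000 nM.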

Compound 4, half-maximal inhibitory concentration: 82900 nM
Compound 4: middle estimate off by 2.1-fold (0.32 log units), on the low side; low and high end bracket the measured number.
By their numbers in this assay, from the lowest: compound 3; then compounds 4 and 2 (each within the scatter of the next); then compound 1.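

Replacing the 4-nitrophenyl in this assay still lowers the number without any oxygen on the new ring (a 2.6-fold lower number from compound 1 to compound 4 (0.42 log units; beyond the scatter)), so the gain seen with compound 3 does not depend on having a methoxy group. The methoxy group still matters, however, as methyl in its place on the aromatic carbon raises the number (a 2.6-fold higher number from compound 3 to compound 4 (0.42 log units; beyond the scatter)). Compound 2 and compound 4 cannot be told apart (a 1.2-fold lower number from compound 2 to compound 4 (0.08 log units; within the scatter)). Nothing measured here explains these steps. As far as these compounds go, how a 3-hydroxyphenyl or 3-aminophenyl group would compare with compound 3 and compound 4 remains open.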